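The compounds below may be only part of what the source reports. "The series", "measured", "known", "first", "only" and "open" are said of these compounds alone.

Working notes on the series in a functional assay on HL-60 cells (Homo sapiens) for antiproliferative activity; on this read-out higher numbers stand for weaker inhibition and lower numbers for stronger inhibition. Compound 1 `COc1cc(/C=C/c2cccc(OC)c2O)cc(OC)c1` gives 3500 nM and compound 2 `COc1cc(OC)cc(-c2ccc(-c3ccc(O)cc3)cc2)c1` gives 2500 nM. Compound 3 `COc1cc(OC)cc(-c2cccc(-c3ccc(O)cc3)c2)c1` gives 4800 nM. That value lies within the scatter of the values of both other measured compounds, so the three cannot be ranked on these numbers.

Compound 4 `COc1ccc(-c2cccc(-c3cc(OC)cc(OC)c3)c2)cc1` differs from compound 3 in one place: 4-hydroxyphenyl to 4-methoxyphenyl, with methyl in place of hydrogen on an oxygen on an aromatic ring. Within the data shown here, no measured pair shows this change, so the data give no direct size or direction for it.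

Among the measured compounds shown here, the only guide is the narrow spread of the measured values, with compound 2 at 2500 nM and compound 3 at 4800 nM still within the scatter of each other despite their structural difference. On that basis, no step beyond the scatter is expected in this assay, and only a slight lean towards a higher number is assumed. The estimated change is a 1.1-fold higher number from compound 3 to compound 4 (0.06 log units; within the scatter). For the measured compounds named here, the expected value for compound 4 is 5500 nM, with an estimated range of 2000 nM to 15000 nM, kept wide since no measured step supports it.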

Compound 4, half-maximal inhibitory concentration: 50000 nM
Compound 4: the middle estimate sits 9.1-fold (0.96 log units) below what was measured; measured number outside the range, above it.
By their numbers in this assay, from the lowest: compounds 2, 1 and 3 (each within the scatter of the next); then compound 4.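

In this assay, among these compounds, methyl in place of hydrogen on an oxygen on an aromatic ring gives a 10-fold higher number from compound 3 to compound 4 (1.02 log units; beyond the scatter), the first step to lie beyond the scatter. Among the compounds shown here, the flat picture left by the earlier compounds, none of which were linked by a measured step, therefore does not extend to this place: going from 4-hydroxyphenyl to 4-methoxyphenyl is a large change on this read-out, and it takes only the one added carbon. Nothing measured on these compounds speaks to the reason for this step.

From the compounds shown here alone, it remains open whether the loss of the hydrogen or the arrival of the methyl drives the step, and an amine or a carboxylic acid in place of the hydroxy, or an ethoxy in place of the methoxy, would help to separate the two. Going by these compounds, it is equally open whether the same change on the hydroxy of compound 2 or compound 1 would give a step of similar size, so the result holds for this one pair only.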